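The source may hold more compounds than are shown below. What is called first, only, known or untested is meant among the compounds shown, and "the series" means these compounds.

Measured compounds:
- compound 1 `COc1ccc(C(=O)c2ccc3c(ccn3Cc3ccc(C(=O)NO)cc3)c2)cc1`, in an assay on isolated protein for inhibition of polyamine deacetylase HDAC10 (Homo sapiens) (on this read-out higher numbers stand for weaker inhibition and lower numbers for stronger inhibition), compound 1 gives 59800 nM
- compound 2 `COc1cc(C(=O)c2ccc3c(ccn3Cc3ccc(/C=C/C(=O)NO)cc3)c2)cc(OC)c1OC`, for which this assay records "not determined" (no result reported)

Compound 2 therefore stands on no number at all: this assay reports no result for it, and the only figure available in the series comes from compound 1. Compound 3 `COc1ccc(C(=O)c2ccc3c(ccn3Cc3ccc(/C=C/C(=O)NO)cc3)c2)cc1` differs from compound 2 in one place, namely (4-methoxyphenyl in place of 3,4,5-trimethoxyphenyl on a carbonyl carbon). Within the data shown here, no measured pair shares exactly this change, so the size of the step from compound 2 to compound 3 in this assay cannot be read from the data; with compound 2 itself unmeasured, no direction can be claimed beyond the scatter. The expectation for compound 3 can rest only on compound 1, which shares the 4-methoxyphenyl ketone and gives 59800 nM in this assay. On that basis compound 3 is expected to land near 15000 nM, with a range from 3000 nM to 70000 nM.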

Compound 3, half-maximal inhibitory concentration: 7050 nM
Compound 3: middle estimate off by 2.1-fold (0.33 log units), on the high side, within the range that was stated.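

In this assay, among these compounds, the change from hydroxycarbamoyl to 2-(hydroxycarbamoyl)ethenyl on an aromatic carbon, with the 4-methoxyphenyl ketone held the same, gives an 8.5-fold lower number from compound 1 to compound 3 (0.93 log units; beyond the scatter) and so provides the first readable step, one that lies beyond the scatter. Compound 2 has no reported result, so the step from 3,4,5-trimethoxyphenyl to 4-methoxyphenyl on a carbonyl carbon cannot be read. No measurement shown here accounts for the lower number of compound 3.

The compounds shown leave open whether a saturated 2-(hydroxycarbamoyl)ethyl chain or a longer chain would keep the lower number seen with the ethenyl link. They also leave open what a carboxylic acid in place of the hydroxycarbamoyl end, or an amine on the phenyl of the ketone, would do in this assay on this core.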